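The source may report more compounds than this note shows. Statements on the series, on what has been measured and on what is new or still open speak of the compounds shown alone.

Measured compounds:
compound 1 `CCn1c(-c2cnc(C)nc2)nc2c(N[C@H]3CCN(C(=O)C4CCOC4)C3)ncnc21` — 2.3 L/kg
compound 2 `CCC(=O)N1CC[C@H](Oc2ncnc3c2nc(-c2cnc(C)nc2)n3CC)C1` — 2.4 L/kg
compound 3 `CCn1c(-c2ccc(C(F)(F)F)nc2)nc2c(O[C@H]3CCN(C(=O)C4CC4)C3)ncnc21` — 8.3 L/kg

In an ADME assay (Rattus norvegicus, strain Wistar Han) for pharmacokinetics (on this read-out lower numbers stand for narrower distribution and higher numbers for wider distribution into tissues), compound 1 gives 2.3 L/kg, the lowest of the three numbers. Compound 2 stands within the scatter of it, so the two cannot be told apart on this read-out. Within the data shown here, compound 3, which differs from compound 1 in more than one place, lies beyond the scatter with the higher number; no single step links these two, and their values show only that such differences can move the read-out considerably.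

Compound 4 `CCn1c(-c2cnc(C)nc2)nc2c(N[C@H]3CCN(C(=O)C4CC4)C3)ncnc21` is not yet measured. It differs from compound 1 in one place: cyclopropyl in place of oxolan-3-yl on a carbonyl carbon. Among the measured compounds shown here, nothing among the measured compounds isolates this change. Compound 3 carries the cyclopropyl on its carbonyl carbon and gives 8.3 L/kg, yet its other differences leave that pairing unreadable as a single step. The account therefore expects a small shift, upward if any, of about a 1.3-fold higher number from compound 1 to compound 4 (0.12 log units; within the scatter), not clearly beyond the scatter. For compound 4 the estimate in this assay is 3 L/kg, with a range from 1.7 L/kg to 5.5 L/kg.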

Compound 4, volume of distribution: 6.3 L/kg
The estimate for compound 4 lay 2.1-fold (0.32 log units) below the measured number; the measured number lies above the stated range.
By their numbers in this assay, from the lowest: compounds 1 and 2 (each within the scatter of the next); then compounds 4 and 3 (each within the scatter of the next).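

Among these compounds, this is the first single change read at this position: in this assay, cyclopropyl in place of oxolan-3-yl on a carbonyl carbon gives a 2.7-fold higher number from compound 1 to compound 4 (0.44 log units; beyond the scatter). The group on this carbonyl carbon therefore matters for this read-out, since this one change moves the number while the rest of compound 1 stays the same. Nothing measured here explains the step, which stands as an observation only.

The compounds shown leave open whether the ring oxygen of oxolan-3-yl or the ring as a whole accounts for the step, and whether the same change would give a similar step elsewhere in the series. As far as these compounds go, what an amine or a longer carbon chain on this carbonyl carbon would do to the number also remains open.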